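This account rests on a few compounds, and the source may have more. Where it says the series, first, only, none or still open, it means among the compounds named here.

Working notes on the series. Compound 1 `Nc1ncnn2c([C@@H]3O[C@H](CO)[C@@H](O)[C@H]3O)cc(-c3ccccc3)c12` carries a phenyl group on the shared core. In a functional assay on K562 cells (Homo sapiens) for antiproliferative activity, with a stated time of 72 h (on this read-out lower numbers stand for stronger inhibition and higher numbers for weaker inhibition), compound 1 gives only a limit, > 100000 nM, and not a number. Compound 2 `Nc1ncnn2c([C@@H]3O[C@H](CO)[C@@H](O)[C@H]3O)cc(-c3ccc(Cl)cc3)c12` carries a 4-chlorophenyl group at the same place, and in this assay compound 2 gives 47800 nM. That is the only number shown for the set; the one further value is a limit, so compound 2 stands as the sole measured point. The measured step is an at least 2.0-fold lower number from compound 1 to compound 2 (0.32 log units; beyond the scatter), to be read alongside (the limit of > 100000 nM in this assay, at which 1 of the 2 values shown sits).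

Compound 3 `Nc1ncnn2c([C@@H]3O[C@H](CO)[C@@H](O)[C@H]3O)cc(/C=C/c3ccccc3)c12` differs from compound 2 by 2-phenylethenyl in place of 4-chlorophenyl on an aromatic carbon. Going by the values given here, the single measured step concerns chloro in place of hydrogen on an aromatic carbon and bears only loosely on this change, which exchanges the whole group; no measured step exchanges an aryl for an alkenyl group. The expected step is therefore a 1.2-fold lower number from compound 2 to compound 3 (0.08 log units; within the scatter), not beyond the scatter. Compound 3 is estimated at 40000 nM, with a range from 10000 nM to 150000 nM, and with a real chance that only a limit is reported.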

Compound 3, half-maximal inhibitory concentration: 3100 nM
Compound 3: the middle estimate sits 13-fold (1.11 log units) above what was measured; the whole stated range lies above it.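

In this assay, exchanging the whole group on this aromatic carbon of the five-membered ring gives a 15-fold lower number from compound 2 to compound 3 (1.19 log units; beyond the scatter), so the read-out depends on what links the phenyl ring to the shared core and not only on a chloro on that ring. Set against the plain phenyl group, 2-phenylethenyl gives an at least 32-fold lower number from compound 1 to compound 3 (1.50 log units; beyond the scatter), a step that rests on a limit for compound 1 and not on a number: the limit of > 100000 nM in this assay, at which 1 of the 3 values shown sits. With its steps to both other compounds printed as beyond the scatter, compound 3 is the most potent of the three in this assay, and the series now has two measured numbers, so that a change at this place can be sized directly from compound 2.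

The compounds shown leave open whether the double bond or the added carbons account for the step, which a saturated 2-phenylethyl chain or an ethynyl link would help to separate. Also open, on these data alone, is whether a chloro on the phenyl ring of 2-phenylethenyl adds to the step, and whether an amine at the end of a longer chain would be accepted at this place.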